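Swapping an Amide for a Sulfonamide on a Thiourea

The source may report more compounds than this note shows. Statements on the series, on what has been measured and on what is new or still open speak of the compounds shown alone.

Compound 1 `NC(=S)N1CCCc2c(OCCCCCOc3cccc4ccccc34)cccc21` gives > 50000 nM in an ADME assay on Huh-7 cells (Homo sapiens) for cytotoxicity; on this read-out lower numbers stand for higher toxicity in this test and higher numbers for lower toxicity in this test.
Compound 2 `O=C(NC(=S)N1CCc2ccc(OCc3ccccc3)cc21)c1ccccc1` gives 43800 nM in this assay.
Compound 3 `CC(C)(C)c1ccc(C(=O)NC(=S)N2CCc3c(OCCCCCOc4ccc(Cl)cc4)cccc32)cc1` gives > 50000 nM in this assay.

All three readings come from a toxicity test on liver-derived cells. For compound 1 the reading is a limit of the test rather than a number. For compound 3 the reading is likewise a limit, so compound 3 stands at the limit of > 50000 nM in this assay, at which 2 of the 3 values shown sit, where most of this small set sits. Compound 2 returns an actual number, but one that lies close to that limit. Within the data shown here, no two measured compounds differ in only one place, so no single step can be read directly from the data.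

Compound 4 `O=S(=O)(NC(=S)N1CCc2c(OCCCCCOc3ccc(Cl)cc3)cccc21)c1ccccc1` differs from compound 3 by phenylsulfonyl in place of (4-(tert-butyl)phenyl)carbonyl on an amide-type nitrogen. Each of the leaving and entering parts is a single six-membered ring hung on the same nitrogen, and the rest of compound 3 is kept. With all measured values at or near the limit, the expected step of a number no higher from compound 3 to compound 4 (the limit leaves the size open) is none beyond the scatter. Compound 4 is therefore expected to give 50000 nM in this assay, within a range from 25000 nM to 100000 nM, quite possibly again as a limit.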

Compound 4, half-maximal cytotoxic concentration: > 50000 nM
Compound 4 was reported as a limit (the forecaster's own chance of this, stated with the estimate: 65%); the middle value lies on the limit itself.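

Compound 3 and compound 4 both sit at a limit of the test rather than at a number, and the swap between them gives no readable step. Going by these compounds, whether phenylsulfonyl and (4-(tert-butyl)phenyl)carbonyl on this nitrogen truly differ in this assay stays open.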